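The source may report more compounds than this note shows. Statements on the series, on what has been measured and on what is new or still open speak of the compounds shown alone.

Compound 1, with the structure `Cc1nn(C)c2c1C(c1cccc(Cl)c1)=NCCN2C`, and compound 2, with the structure `CCN1CCN=C(c2cccc(Cl)c2)c2c(C)nn(C)c21`, share a core, and in a functional assay on the whole organism for positive allosteric modulation, with Rattus norvegicus as the target (on this read-out higher numbers stand for an effect only at larger amounts of compound and lower numbers for an effect already at smaller amounts), compound 1 gives 0.63 mg/kg while compound 2 gives 0.63 mg/kg. The change between them is methyl in place of hydrogen on a saturated chain carbon bound to a nitrogen on an aromatic ring in a ring, and the step of no change at the digits printed from compound 1 to compound 2 (within the scatter).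

Compound 3, with the structure `Cc1nn(C)c2c1C(c1ccccc1Cl)=NCCN2C`, is built on a different core; how its core differs from that of compound 1 is not broken down here. In this assay compound 3 gives 2.5 mg/kg, the highest of the three numbers and beyond the scatter from both compound 1 and compound 2.

Compound 4, with the structure `CCn1nc(C)c2c1N(C)CCN=C2c1ccccc1Cl`, has not yet been measured. It differs from compound 3 by methyl in place of hydrogen on a saturated chain carbon bound to an aromatic nitrogen. This is the same kind of change as from compound 1 to compound 2, though the carbon there is bound to a nitrogen on an aromatic ring in a ring, here to an aromatic nitrogen. Because no change at the digits printed from compound 1 to compound 2 (within the scatter) showed no change within the scatter, the step from compound 3 to compound 4 is expected to be no change at the digits printed from compound 3 to compound 4 (within the scatter), with compound 4 estimated at 2.5 mg/kg, between 1.2 mg/kg and 5 mg/kg.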

Compound 4, minimum effective dose: 5 mg/kg
Beside the measured number, compound 4's estimate is 2.0-fold (0.30 log units) below it, within the range that was stated.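

In this assay, methyl in place of hydrogen on a saturated chain carbon bound to an aromatic nitrogen gives a 2.0-fold higher number from compound 3 to compound 4 (0.30 log units; within the scatter), so on this core the change does not move the number beyond the scatter. Set beside the earlier step, the change carries from one core to the other without a difference that can be told from the scatter: the same change on two cores in this assay, no change at the digits printed (within the scatter) from compound 1 to compound 2 and a 2.0-fold higher number (0.30 log units; within the scatter) from compound 3 to compound 4, 2.0-fold (0.30 log units) apart, within the scatter of two such steps.

This does not show that the change is neutral on cores in general, since it rests on just two pairs of compounds and the added methyl sits at a different place in each pair. Nor does it rank compound 3 and compound 4 against each other.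

The compounds shown leave open whether a longer chain, such as propyl or butyl, would keep the number within the scatter at either place. They also leave open what an amine or a carboxylic acid at the end of such a chain would do.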